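Replacing an Isothiocyanate with an Amino Group on a Shared Core

This account rests on a few compounds, and the source may have more. Where it says the series, first, only, none or still open, it means among the compounds named here.

Measured so far in an ADME assay on the whole organism (thoracic aorta) with Rattus norvegicus as the target; a lower number here means a smaller maximal response, a higher number a larger maximal response:
compound 1, `Cc1ccc(CC2=NCCN2)cc1`, gives 5%
compound 2, `S=C=Nc1ccc(CC2=NCCN2)cc1`, gives 100%

Compound 2 stands highest of the two numbers measured; its nearest neighbour is compound 1, and the step of a number 95 percentage points higher from compound 1 to compound 2 (beyond the scatter) was a large one, reached by placing a group of 3 heavy atoms (1 carbon, 1 nitrogen, 1 sulfur; no ring) in place of one carbon atom, on an aromatic carbon.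

Compound 3, `Nc1ccc(CC2=NCCN2)cc1`, has not been measured. It differs from compound 2 as follows: one nitrogen atom in place of a group of 3 heavy atoms (1 carbon, 1 nitrogen, 1 sulfur; no ring), on an aromatic carbon. Among the measured compounds shown here, no measured step covers this exact exchange; the only step at hand is the one from compound 1 to compound 2, which shows that the group on that aromatic carbon can move the largest response a long way. Since the amino group is neither the methyl of compound 1 nor the isothiocyanate of compound 2, a downward step from compound 2 is expected, estimated at a number 50 percentage points lower from compound 2 to compound 3 (beyond the scatter). The estimate for compound 3 in this assay is therefore 50%, within a range from 10% to 95%.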

Compound 3, largest response reached (Emax), in percent of the reference or control that the assay uses: 9%
Beside the measured number, compound 3's estimate is 41 percentage points above it, outside the stated range (below it).
By their numbers in this assay, from the lowest: compounds 1 and 3 (each within the scatter of the next); then compound 2.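

Setting amino in place of the isothiocyanate on this aromatic carbon gives, in this assay, a number 91 percentage points lower from compound 2 to compound 3 (beyond the scatter), so the high response of compound 2 does not carry over to this small nitrogen group. Setting amino in place of methyl gives a number 4 percentage points higher from compound 1 to compound 3 (within the scatter), which means that this assay does not separate these two groups, and among the three compounds shown only the isothiocyanate stands apart from the others. Nothing measured here explains why this one group differs so sharply from the other two.

The three compounds cannot show which part of the isothiocyanate matters, and an isocyanate, with oxygen in place of sulfur, or a thiourea on the same aromatic carbon would help to settle that. It also remains open whether a hydroxyl group or a longer chain at this place would stay level with compound 1 and compound 3 or come closer to compound 2, so the three groups shown mark only a small part of what this position might accept.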